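This account rests on a few compounds, and the source may have more. Where it says the series, first, only, none or still open, it means among the compounds named here.

Compound 2, `CCC(=O)NC1CCCN(S(=O)(=O)c2ccc(F)cc2)C1`, is measured in a functional assay on the whole organism with Mus musculus as the target, with a stated time of 30 min (a higher number here means that more compound is needed for the effect, a lower number that less compound is needed), at 1 mg/kg. Within the data shown here, its nearest neighbour in these data is compound 1, `CC(C)S(=O)(=O)NC1CCCN(S(=O)(=O)c2ccc(F)cc2)C1`, which in this assay gives 1 mg/kg; the single measured step, no change at the digits printed from compound 1 to compound 2 (within the scatter), shows that the two stand level within the scatter.

The next compound, compound 3, `CC(=O)NCC1CCCN(S(=O)(=O)c2ccc(F)cc2)C1`, differs from compound 2 in one place: acetamidomethyl in place of propanoylamino on a saturated ring carbon. Among the measured compounds shown here, the only measured step available, no change at the digits printed from compound 1 to compound 2 (within the scatter), bears on this change just indirectly, since it swapped the group on the amine nitrogen while the group's attachment to the ring carbon stayed the same, whereas the step to compound 3 moves the same atoms into a different arrangement on that ring carbon. That measured step was flat, and nothing in the data points to a particular direction for the rearrangement. The account therefore expects no step beyond the scatter, no change at the digits printed from compound 2 to compound 3 (within the scatter), in this assay. For compound 3 the estimated value in this assay is 1 mg/kg, with a range from 0.4 mg/kg to 3 mg/kg.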

Compound 3, minimum effective dose: 10 mg/kg
The estimate for compound 3 lay 10-fold (1.00 log units) below the measured number; measured number above the stated range.
By their numbers in this assay, from the lowest: compounds 1 and 2 (each within the scatter of the next); then compound 3.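

In this assay, the change to acetamidomethyl in place of propanoylamino on the saturated ring carbon gives a 10-fold higher number from compound 2 to compound 3 (1.00 log units; beyond the scatter), so this position responds to how the atoms are arranged, even though the heavy atoms, the double bond, the hydrogen-bond donor and the hydrogen-bond acceptor counted for the two groups are the same. The flat step, no change at the digits printed from compound 1 to compound 2 (within the scatter), had shown only that propanoyl and isopropylsulfonyl stand level on the amine nitrogen attached to the ring carbon, whereas acetamidomethyl in place of (isopropylsulfonyl)amino gives a 10-fold higher number from compound 1 to compound 3 (1.00 log units; beyond the scatter), so that tolerance does not extend to compound 3. No measurement given here accounts for this difference.

Compound 3 alters two things at once, placing a carbon on the ring ahead of the amide nitrogen and carrying acetyl rather than propanoyl, so the compounds shown do not tell which of these goes with the higher number. From the compounds shown here alone, a propanoylaminomethyl group or an acetylamino group at this position would separate the two, and how a free amine or a longer chain would fare there also remains open.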